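Swapping Propylamino for Propoxy on a Shared Core

The source may report more compounds than this note shows. Statements on the series, on what has been measured and on what is new or still open speak of the compounds shown alone.

Of the compounds shown here, three built on one shared core have been tested in an ADME assay on Akata cells (Homo sapiens) for cytotoxicity, with a stated time of 7 days; a lower number here means that less compound is tolerated, a higher number that more compound is tolerated. Compound 1 `CCCSc1nc(N)nc2c1ncn2/C=C1/CC1(CO)CO` carries a propylsulfanyl group; in this assay compound 1 gives only > 20000 nM, a limit of the assay rather than a number. Compound 2 `Nc1nc(NC2CC2)c2ncn(/C=C3/CC3(CO)CO)c2n1` carries a cyclopropylamino group instead, and compound 2 likewise gives the limit > 20000 nM. Compound 3 `CCCNc1nc(N)nc2c1ncn2/C=C1/CC1(CO)CO` carries a propylamino group, and compound 3 gives the limit > 24000 nM. All three values are limits, so the steps a step that the two limits leave unreadable from compound 1 to compound 2, a step that the two limits leave unreadable from compound 1 to compound 3 and a step that the two limits leave unreadable from compound 2 to compound 3 cannot be read in size. Two values sit at the limit of > 20000 nM in this assay, at which 2 of the 3 values shown sit, and one at the limit of > 24000 nM in this assay, at which 1 of the 3 values shown sits; compound 3 thus stands alongside the others, tolerated up to where the assay stops counting.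

Compound 4 `CCCOc1nc(N)nc2c1ncn2/C=C1/CC1(CO)CO` differs from compound 3 by propoxy in place of propylamino on an aromatic carbon. Going by the values given here, no measured step bears readably on this change, and none of the three compounds yields a number. Compound 4 is therefore expected to be tolerated in this assay much as compound 3 is. The step that the limit leaves unreadable from compound 3 to compound 4 is expected to stay within the usual scatter. The estimate for compound 4 is 30000 nM, between 15000 nM and 100000 nM, most probably reported again only as a limit.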

Compound 4, half-maximal cytotoxic concentration: > 20000 nM
Compound 4 ended at the assay's limit; the forecaster's own chance of this, stated with the estimate: 85%; the middle value lies beyond the limit too.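

In this assay compound 4 gives > 20000 nM, a limit of the assay and not a number, so its steps from compound 1, compound 2 and compound 3 cannot be read in size. The compounds shown leave open whether propoxy, propylamino, cyclopropylamino and propylsulfanyl differ at all in how much compound is tolerated.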